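Swapping a Nitro Group for a Carboxylic Acid

A few compounds are considered here, and "the series" means these few. Any claim that something is new, unique, unknown or untested is made for them only; others in the source may bear on it.

Of the compounds shown here, two sharing one core have been tested in a functional assay on PC-3 cells (Homo sapiens) for inhibition; on this read-out lower numbers stand for stronger inhibition and higher numbers for weaker inhibition. Compound 1 `COc1cc2nc(N3CCN(C(=O)c4ccc(C(F)(F)F)cc4)CC3)nc(N)c2cc1OC` carries an amide-linked aryl group; in this assay compound 1 gives > 100000 nM, which is a limit of the assay rather than a number. Compound 2 `COc1cc2nc(N3CCN(S(=O)(=O)c4ccccc4[N+](=O)[O-])CC3)nc(N)c2cc1OC` instead carries a sulfonyl-linked 2-nitrophenyl group, and in this assay compound 2 gives 35000 nM. The other value is the limit of > 100000 nM in this assay, at which 1 of the 2 values shown sits, belonging to compound 1. For the measured compounds named here, compound 2 therefore stands as the only compound with a determined concentration, and no measured step between two compounds is available.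

Compound 3 `COc1cc2nc(N3CCN(S(=O)(=O)c4cccc(C(=O)O)c4)CC3)nc(N)c2cc1OC` differs from compound 2 in one place: 3-carboxyphenyl in place of 2-nitrophenyl on a sulfonyl sulfur. Going by the values given here, with no measured step for a change of this kind, the size of the step from compound 2 to compound 3 can only be guessed. Both measured compounds are weak, and a single change on one ring is expected to move the result only modestly, so the estimated step is a 1.4-fold higher number from compound 2 to compound 3 (0.15 log units; within the scatter). Compound 3 is thus expected to give about 50000 nM, plausibly between 15000 nM and 200000 nM, with a fair chance that only a limit is reported.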

Compound 3, half-maximal inhibitory concentration: 53000 nM
Estimate against measurement, compound 3: 1.1-fold (0.03 log units) below, and the stated range covers the measured number.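

In this assay, for the compounds shown here, the exchange on the sulfonyl sulfur gives a 1.5-fold higher number from compound 2 to compound 3 (0.18 log units; within the scatter), the first measured step at this place, and it means that compound 2 and compound 3 cannot be told apart. Two quite different groups, a 2-nitrophenyl and a 3-carboxyphenyl, are therefore accepted here with no readable difference, and both compounds stay in the same weak range, with compound 3 at 53000 nM. No information shown here bears on why these two values match, so this agreement has no explanation on the present data.

Going by these compounds alone, two things differ at once in this change, the group on the ring and the number in its name, so the single step cannot show what each does alone, and two values that match may hide effects that cancel. Still open, from the compounds shown here alone, is whether a 3-nitrophenyl or 2-carboxyphenyl group would give a similar number, and whether an amine in place of the carboxylic acid, or a plain phenyl ring with no group on it, would move the read-out beyond the usual scatter.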